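Replacing 4-hydroxy-2-methylphenyl with 4-ethylphenyl

This account rests on a few compounds, and the source may have more. Where it says the series, first, only, none or still open, it means among the compounds named here.

Compound 1 `Cc1ccc(C2=NN(c3ccc(S(C)(=O)=O)cc3)C(=O)CC2)cc1` gives 290 nM
Compound 2 `Cc1cc(O)ccc1C1=NN(c2ccc(S(C)(=O)=O)cc2)C(=O)CC1` gives 27900 nM

Both numbers come from a functional assay on CAKI-1 cells (Homo sapiens) for inhibition, read by sulforhodamine B assay, with a stated time of 48 h (a higher number here means a weaker inhibitor of growth, a lower number a stronger inhibitor of growth), and compound 2 stands highest of the two at 27900 nM so it is the weaker growth inhibitor of the pair. Compound 3 `CCc1ccc(C2=NN(c3ccc(S(C)(=O)=O)cc3)C(=O)CC2)cc1` differs from compound 2 in one place, on a carbon with a double bond to nitrogen, where 4-ethylphenyl stands in place of 4-hydroxy-2-methylphenyl (4-ethylphenyl in place of 4-hydroxy-2-methylphenyl on a carbon with a double bond to nitrogen). Within the data shown here, the one measured step that bears on this is a 96-fold higher number from compound 1 to compound 2 (1.98 log units; beyond the scatter) with 4-hydroxy-2-methylphenyl in place of 4-methylphenyl, a large step beyond the scatter. With that group gone from compound 3 and compound 1 at 290 nM as a guide, a large step towards a lower number is expected in this assay of nearly the same size. Among the measured compounds shown here, no measured compound yet carries 4-ethylphenyl, so the expectation stays broad. The estimated change is a 70-fold lower number from compound 2 to compound 3 (1.84 log units; beyond the scatter) on this reasoning. Compound 3 is therefore expected at 400 nM with 120 nM to 1500 nM as the estimated range.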

Compound 3, concentration for 50% growth inhibition: 1000 nM
Compound 3: the middle estimate sits 2.5-fold (0.40 log units) below what was measured; low and high end bracket the measured number.
By their numbers in this assay, from the lowest: compound 1; then compound 3; then compound 2.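

Moving to the 4-ethylphenyl group gives a 28-fold lower number from compound 2 to compound 3 (1.45 log units; beyond the scatter) in this assay and so restores much of the growth inhibition that compound 2 lacks, which shows that the weakness of compound 2 belongs to its 4-hydroxy-2-methylphenyl group and not to having an aromatic ring on this carbon. The position still responds to small changes: the extension of 4-methylphenyl to 4-ethylphenyl gives a 3.4-fold higher number from compound 1 to compound 3 (0.54 log units; beyond the scatter) as a modest step that lies beyond the scatter, so the longer group is not simply interchangeable with the shorter one, and compound 1 remains the strongest of the three. Nothing among the data available explains why these groups differ in this way.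

The compounds shown leave open whether the hydroxy group or the methyl group of 4-hydroxy-2-methylphenyl accounts for the loss, since the two always appear together here, and a phenyl ring carrying only the hydroxy group would separate them. They also leave open how a longer chain such as propyl, or an amine in the same place on the ring, would fare on this carbon.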